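Swapping carboxy for hydroxymethyl on compound 1

The source may hold more compounds than are shown below. What is called first, only, known or untested is meant among the compounds shown, and "the series" means these compounds.

- compound 1 `COc1c(-c2occ(C)c2C(=O)O)ccc2c1CCCC2(C)C`: 25.5 uM
- compound 2 `CCc1cccc2c(O)c(-c3occ(C)c3C(=O)O)ccc12`: 3.4 uM
- compound 3 `Cc1coc(-c2ccc3c(c2O)CCC3)c1C(=O)O`: 30.2 uM

In a functional assay on SK-BR-3 cells (Homo sapiens) for cytotoxicity, read by sulforhodamine B assay, with a stated time of 3 days (on this read-out lower numbers stand for an effect already at smaller amounts and higher numbers for an effect only at larger amounts of compound), compound 1 gives 25.5 uM. This lies within the scatter of compound 3 at 30.2 uM, while compound 2 stands clearly lower at 3.4 uM. Compound 1 therefore sits in the upper pair of the three numbers.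

The next compound, compound 4 `COc1c(-c2occ(C)c2CO)ccc2c1CCCC2(C)C`, keeps the core of compound 1 but carries hydroxymethyl in place of carboxy on an aromatic carbon. Among the measured compounds shown here, all three measured compounds carry carboxy, so no measured pair shows directly what this swap does, and any forecast is uncertain. A modest move toward a lower number is expected in this assay, about as large as the usual scatter, and no real change would not be surprising. The estimated step is a 2.1-fold lower number from compound 1 to compound 4 (0.33 log units; beyond the scatter). For compound 4 the estimated value is 12 uM, with an expected range from 4 uM to 40 uM.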

Compound 4, concentration for half-maximal effect: 23.7 uM
Compound 4: the middle estimate sits 2.0-fold (0.30 log units) below what was measured; measured number inside the range.
By their numbers in this assay, from the lowest: compound 2; then compounds 4, 1 and 3 (each within the scatter of the next).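

In this assay, among the compounds shown here, the swap of carboxy for hydroxymethyl on the five-membered aromatic ring amounts to a 1.1-fold lower number from compound 1 to compound 4 (0.03 log units; within the scatter) and so gives the first direct reading of this change, which leaves the two compounds indistinguishable. On the core of compound 1, then, carboxy at this place is not needed for a number of this size, and hydroxymethyl serves equally well in this read-out. Nothing available explains why the two groups read alike.

On these data alone, this is a single pair on a single core, so it remains open whether the same swap would read the same way on the core of compound 2, which stands clearly lower. Also open, as far as these compounds go, is how other groups at this place would read, such as an aminomethyl group, a methyl ester or a primary amide.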